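Adding One Methyl to the Alcohol Chain of Compound 2

A few compounds are considered here, and "the series" means these few. Any claim that something is new, unique, unknown or untested is made for them only; others in the source may bear on it.

Going by the values given here, in a functional assay on CH1 cells (Homo sapiens) for inhibition, read by sulforhodamine B assay, with a stated time of 96 h (a lower number here means a stronger inhibitor of growth, a higher number a weaker inhibitor of growth), compound 2 `CC[C@@H](Nc1nc(NCc2ccccn2)c2ncn(C(C)C)c2n1)C(C)O` gives 20000 nM, the only actual number so far. Compound 1 `CC[C@@H](Nc1nc(NCc2ccccn2)c2ncn(C(C)C)c2n1)C(C)(C)O` reaches only a limit of the assay, > 50000 nM. Among the compounds with values here, the single measured step, an at least 2.5-fold lower number from compound 1 to compound 2 (0.39 log units; beyond the scatter), replaces methyl with hydrogen and lies beyond the scatter. Compound 3 `CCC(O)[C@@H](CC)Nc1nc(NCc2ccccn2)c2ncn(C(C)C)c2n1` instead gains carbon, (methyl in place of hydrogen on a saturated chain carbon, two bonds along the chain from an oxygen on a saturated carbon), turning 1-hydroxyethyl into 1-hydroxypropyl. Since methyl loss strengthened inhibition in an at least 2.5-fold lower number from compound 1 to compound 2 (0.39 log units; beyond the scatter), though at a different carbon, a modest shift toward weaker inhibition is expected in this assay, an estimated 1.4-fold higher number from compound 2 to compound 3 (0.13 log units; within the scatter). Compound 3 is estimated at 27000 nM, with an expected range of 10000 nM to 50000 nM.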

Compound 3, concentration for 50% growth inhibition: 26000 nM
The estimate for compound 3 lay 1.0-fold (0.02 log units) above the measured number, within the range that was stated.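

In this assay, methyl in place of hydrogen on a saturated chain carbon, two bonds along the chain from an oxygen on a saturated carbon, gives a 1.3-fold higher number from compound 2 to compound 3 (0.11 log units; within the scatter), so 1-hydroxyethyl and 1-hydroxypropyl cannot be told apart here. The other comparison, an at least 1.9-fold lower number from compound 1 to compound 3 (0.28 log units; that floor lies within the scatter), rests on a limit and sets no order between the two compounds: the limit of > 50000 nM in this assay, at which 1 of the 3 values shown sits. As far as these compounds go, whether a longer chain at this place, or an amine or a carboxylic acid on it, would move the number beyond the scatter stays open.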